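Benzoyl to acetyl: forward note on compound 4

This account rests on a few compounds, and the source may have more. Where it says the series, first, only, none or still open, it means among the compounds named here.

The series is read in a functional assay on MDA-MB-231 cells (Homo sapiens) for cytotoxicity, read by sulforhodamine B assay, with a stated time of 72 h; on this read-out higher numbers stand for weaker inhibition of growth and lower numbers for stronger inhibition of growth. Among the measured compounds shown here, compound 1 `O=C(Nc1ccccc1C(F)(F)F)C1CCc2ccccc2N1C(=O)c1ccccc1` gives 5290 nM, the second highest of the three numbers so far. Compound 2 `O=C(Nc1ccccc1O)C1CCc2ccccc2N1C(=O)c1ccccc1` gives 4210 nM, and the step of a 1.3-fold lower number from compound 1 to compound 2 (0.10 log units; within the scatter) stays within the scatter. For the measured compounds named here, compound 3 `O=C(Nc1ccccc1O)C1CCc2ccccc2N1C(=O)c1cccc(Cl)c1` gives 10600 nM; the step of a 2.5-fold higher number from compound 2 to compound 3 (0.40 log units; beyond the scatter) is the only change that reached beyond the scatter, and it concerns the ring of the benzoyl group, not the amide-bearing side chain. Compound 1 and compound 3 sit within the scatter of each other.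

Compound 4 `CC(=O)N1c2ccccc2CCC1C(=O)Nc1ccccc1C(F)(F)F` differs from compound 1 by methyl in place of phenyl on a carbonyl carbon, that is, benzoyl to acetyl. Going by the values given here, no measured step touches the carbonyl carbon whose other neighbour is the amide-type nitrogen in a ring; the two steps recorded sit on other parts of the molecule and give no direct guidance. The only bearing they have is that substituent changes on the benzoyl ring moved the numbers modestly at most, so the expected step in this assay is none beyond the scatter, with wide uncertainty in either direction. On that basis compound 4 is estimated at 5500 nM, expected between 2500 nM and 13000 nM, a step of a 1.0-fold higher number from compound 1 to compound 4 (0.02 log units; within the scatter) that is expected rather than known.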

Compound 4, concentration for 50% growth inhibition: > 80000 nM
Compound 4: only a limit was reported; the forecaster's own chance of this, stated with the estimate: 10%; at least 14-fold (1.16 log units) between middle value and limit.
By their numbers in this assay, from the lowest: compounds 2, 1 and 3 (each within the scatter of the next, the first and the last beyond it). At a limit, above all of these: compound 4.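

In this assay, the group on the carbonyl carbon whose other neighbour is the amide-type nitrogen in a ring is the most sensitive place touched so far: methyl in place of phenyl gives an at least 15-fold higher number from compound 1 to compound 4 (1.17 log units; beyond the scatter). The earlier changes on the aromatic rings gave only a 1.3-fold lower number from compound 1 to compound 2 (0.10 log units; within the scatter) and a 2.5-fold higher number from compound 2 to compound 3 (0.40 log units; beyond the scatter), so decorating the benzoyl ring shifted the number modestly, while taking the whole phenyl away cost far more. The reading for compound 4 is a limit of the assay and not a number, so the full size of this step stays unknown: the limit of > 80000 nM in this assay, at which 1 of the 4 values shown sits.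

Whether the aromatic ring itself is what counts stays open, since the compounds shown hold nothing on this carbonyl carbon other than phenyl, chloro-substituted phenyl and methyl, and a cyclohexyl ring, a benzyl group or a longer chain such as butyl would separate ring, aromatic ring and chain length. Also open, as far as these compounds go, is whether methyl in place of phenyl reads the same on compound 2, which carries hydroxy in place of trifluoromethyl.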